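This account rests on a few compounds, and the source may have more. Where it says the series, first, only, none or still open, it means among the compounds named here.

Measured in an ADME assay on HaCaT cells (Homo sapiens) for cytotoxicity, read by MTT assay, with a stated time of 48 h; on this read-out lower numbers stand for stronger inhibition and higher numbers for weaker inhibition:
- compound 1 `Fc1ccc(-c2nn(-c3ccccc3)cc2-c2nc3ccccc3[nH]2)cc1`: > 50000 nM (a limit)
- compound 2 `Fc1ccc(-c2nn(-c3ccccc3)cc2-c2nc3cc(F)ccc3[nH]2)cc1`: > 50000 nM (a limit)
- compound 3 `Fc1ccc(-c2nn(-c3ccccc3)cc2-c2nc3cc(Br)ccc3[nH]2)cc1`: 21800 nM

Compound 2 has no number of its own and stands on (the limit of > 50000 nM in this assay, at which 2 of the 3 values shown sit). Compound 4 `Fc1ccc2[nH]c(-c3cn(-c4ccccc4)nc3-c3ccc(Cl)cc3)nc2c1` has not yet been measured. It differs from compound 2 by chloro in place of fluoro on an aromatic carbon. This is chloro in place of fluoro on an aromatic carbon, or 4-fluorophenyl to 4-chlorophenyl.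

Among the measured compounds shown here, no measured step touches this 4-fluorophenyl group, and no chloro compound has a value yet, so the evidence is indirect. Adding fluoro gives a step that the two limits leave unreadable from compound 1 to compound 2. Adding bromo gives an at least 2.2-fold lower number from compound 1 to compound 3 (0.36 log units; beyond the scatter). For the measured compounds named here, the closest precedent, a heavier halogen replacing fluoro at a different place, gives an at least 2.2-fold lower number from compound 2 to compound 3 (0.36 log units; beyond the scatter). Compound 3 thus shows that one halogen exchange can bring a number into the readable range, at 21800 nM. Chloro is a different halogen at a different place, so that precedent carries over only weakly.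

In this assay, a small shift toward lower numbers is expected, and compound 4 may well stay at the limit. The estimated change is an at least 1.3-fold lower number from compound 2 to compound 4 (0.11 log units; that floor lies within the scatter). For compound 4 the expected value is 38000 nM, with an estimated range from 17000 nM to 80000 nM.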

Compound 4, half-maximal inhibitory concentration: > 50000 nM
Compound 4: a limit, no number; the forecaster's own chance of this, stated with the estimate: 50%; at least 1.3-fold (0.11 log units) between middle value and limit.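

In this assay compound 4 gives > 50000 nM, which is a limit and not a number. Compound 2 also stands at a limit, so the step between compound 2 and compound 4 cannot be read: the limit of > 50000 nM in this assay, at which 3 of the 4 values shown sit. The compounds shown leave open how far 4-chlorophenyl and 4-fluorophenyl differ in this read-out, if they differ at all.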